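Amide variation on the shared core: pyridin-2-yl to pyridin-4-yl

The source may hold more compounds than are shown below. What is called first, only, known or untested is meant among the compounds shown, and "the series" means these compounds.

The series rests on the acid compound 1 `COc1cc2c(cc1OC)C(CC(=O)O)CC2` and two amides made from it, compound 2 `COc1cc2c(cc1OC)C(CC(=O)Nc1ccc(C)cc1)CC2` and compound 3 `COc1cc2c(cc1OC)C(CC(=O)Nc1ccccn1)CC2`. In a functional assay on the whole organism (strain Wistar) for inhibition, with Rattus norvegicus as the target, read by paw edema, with a stated time of 3 h, at a dose of 100 mg/kg (on this read-out higher numbers stand for more inhibition at the one dose given (going by the name of the read-out) and lower numbers for less inhibition), compound 1 gives 27.5%, compound 2 gives 34.8% and compound 3 gives 30.4%. Every measured step is within the scatter: a number 7.3 percentage points higher from compound 1 to compound 2 (within the scatter), a number 2.9 percentage points higher from compound 1 to compound 3 (within the scatter) and a number 4.4 percentage points lower from compound 2 to compound 3 (within the scatter). Compound 3 therefore sits among numbers that cannot be told apart; its nearest neighbour on the read-out is compound 1 and its furthest is compound 2, both within the scatter.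

Compound 4 `COc1cc2c(cc1OC)C(CC(=O)Nc1ccncc1)CC2` differs from compound 3 in one place: pyridin-4-yl in place of pyridin-2-yl on an amide-type nitrogen. Going by the values given here, no measured pair shows this exact exchange. Among the compounds with values here, the only step that bears on it is the exchange on the amide-type nitrogen from compound 2 to compound 3, which was within the scatter. Nothing here suggests a step beyond the scatter in this assay; the expected step is a number 0.6 percentage points higher from compound 3 to compound 4 (within the scatter). Compound 4 is estimated at 31%, with a range from 21% to 41%.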

Compound 4, a percentage reported as inhibition, in the whole organism at one dose (the size of the read-out at that dose, not a potency): 42%
The estimate for compound 4 lay 11 percentage points below the measured number; the whole stated range lies below it.
By their numbers in this assay, from the lowest: compounds 1, 3, 2 and 4 (each within the scatter of the next, the first and the last beyond it).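

In this assay, going by these compounds alone, the exchange of pyridin-2-yl for pyridin-4-yl on the amide-type nitrogen gives a number 11.6 percentage points higher from compound 3 to compound 4 (beyond the scatter), the first step at this place to leave the scatter, and it comes from two groups with the same atoms joined differently. Against the acid, the change to (pyridin-4-yl)amino gives a number 14.5 percentage points higher from compound 1 to compound 4 (beyond the scatter), while the exchange of 4-methylphenyl for pyridin-4-yl gives a number 7.2 percentage points higher from compound 2 to compound 4 (within the scatter), so these two amides are not separated at this dose. No measurement at hand accounts for the step between the two pyridinyl amides.

Where pyridin-3-yl on the same nitrogen would fall relative to these two pyridinyl amides remains open. Also open, going by these compounds, is whether pyridin-4-ylmethyl in place of pyridin-4-yl would keep the step over the acid.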